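A side chain change awaiting its cytotoxicity number

The source may report more compounds than this note shows. Statements on the series, on what has been measured and on what is new or still open speak of the compounds shown alone.

Measured so far in a functional assay on HCT-116 cells (Homo sapiens) for cytotoxicity, read by MTT assay, with a stated time of 72 h (on this read-out lower numbers stand for stronger inhibition and higher numbers for weaker inhibition), are two compounds:

- compound 1 `O=C1c2c[n+]([O-])c3ccccc3c2C(=O)c2c1c1ccccc1n2CCCCN1CCNCC1` with 700 nM
- compound 2 `CN1CCN(CCCCCn2c3c(c4ccccc42)C(=O)c2c[n+]([O-])c4ccccc4c2C3=O)CC1` with 1220 nM

On these two numbers, compound 2 lies within the scatter of compound 1, so neither can be ranked over the other. Compound 3 `O=C1c2c[n+]([O-])c3ccccc3c2C(=O)c2c1c1ccccc1n2CCCN1CCC(O)CC1` has not yet been measured. The difference that leads to it from compound 2 is 4-hydroxypiperidin-1-yl in place of 2-(4-methylpiperazin-1-yl)ethyl on a saturated chain carbon, three bonds along the chain from an aromatic nitrogen and it amounts to 4-hydroxypiperidin-1-yl in place of 2-(4-methylpiperazin-1-yl)ethyl on a saturated chain carbon, three bonds along the chain from an aromatic nitrogen.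

Going by the values given here, only one measured step bears on this, and only in part. It is a 1.7-fold higher number from compound 1 to compound 2 (0.24 log units; within the scatter) and it also alters the end of the chain, with (4-methylpiperazin-1-yl)methyl in place of piperazin-1-yl. Among the compounds with values here, no measured compound carries 4-hydroxypiperidin-1-yl, so the guidance is thin and the range must stay wide. No step beyond the scatter is therefore expected in this assay and the estimate is a 1.4-fold lower number from compound 2 to compound 3 (0.13 log units; within the scatter) in all. For compound 3 the estimated value is 900 nM with an expected range from 300 nM to 2700 nM on this estimate.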

Compound 3, half-maximal inhibitory concentration: 190 nM
For compound 3 the middle estimate is 4.7-fold (0.68 log units) above the measured one; the whole stated range lies above it.
By their numbers in this assay, from the lowest: compound 3; then compounds 1 and 2 (each within the scatter of the next).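

In this assay, going by these compounds alone, the end of the side chain turns out to matter: replacing 5-(4-methylpiperazin-1-yl)pentyl with 3-(4-hydroxypiperidin-1-yl)propyl gives a 6.4-fold lower number from compound 2 to compound 3 (0.81 log units; beyond the scatter), whereas the only earlier step stayed within the scatter. The comparison with the other piperazine compound points the same way, with 4-hydroxypiperidin-1-yl in place of (piperazin-1-yl)methyl on the saturated chain carbon, three bonds along the chain from an aromatic nitrogen, giving a 3.7-fold lower number from compound 1 to compound 3 (0.57 log units; beyond the scatter), so compound 3 stands apart from both earlier compounds by modest steps beyond the scatter. Nothing available accounts for why this change lowers the number.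

Because compound 3 differs from compound 1 and compound 2 in both the ring at the chain end and the chain length, the compounds shown cannot assign the steps to the hydroxy group, the piperidine ring or the shorter chain. As far as these compounds go, it remains open whether a plain piperidin-1-yl or a morpholin-4-yl on the same chain, or a 4-(4-hydroxypiperidin-1-yl)butyl chain on the shared core, would keep the lower number.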